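A few compounds are considered here, and "the series" means these few. Any claim that something is new, unique, unknown or untested is made for them only; others in the source may bear on it.

Going by the values given here, compound 2 `N#Cc1cccc(COc2ccccc2C(=O)Nc2cccnc2)c1` gives 60700 nM in an assay on lysate for inhibition of phosphatidylcholine:ceramide cholinephosphotransferase 2 (Homo sapiens), read by HPLC, with stated times of 30 min and 2 h (on this read-out higher numbers stand for weaker inhibition and lower numbers for stronger inhibition), the higher of the two numbers measured so far; the other, compound 1 `O=C(Nc1cccnc1)c1ccccc1OCc1cccc(F)c1`, gives 1600 nM in this assay. Among the compounds with values here, the one measured step, a 38-fold higher number from compound 1 to compound 2 (1.58 log units; beyond the scatter), is the only guide available. Compound 3 `Cc1ccc(Cl)cc1COc1ccccc1C(=O)Nc1cccnc1` differs from compound 2 by 5-chloro-2-methylphenyl in place of 3-cyanophenyl on a saturated chain carbon bound to an oxygen on an aromatic ring. This change removes the group that, in the step from compound 1 to compound 2, accompanied the large rise in the number, and brings in a group without a hydrogen-bond acceptor, as with compound 1. Within the data shown here, a large step toward a lower number is therefore expected for compound 3, of about a 40-fold lower number from compound 2 to compound 3 (1.61 log units; beyond the scatter), although no measured step covers the chloro and methyl substituents themselves. Compound 3 is thus estimated at 1500 nM in this assay, with a range from 300 nM to 8000 nM.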

Compound 3, half-maximal inhibitory concentration: 1100 nM
Estimate against measurement, compound 3: 1.4-fold (0.13 log units) above; the range from low to high includes it.
By their numbers in this assay, from the lowest: compounds 3 and 1 (each within the scatter of the next); then compound 2.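

In this assay, the saturated chain carbon bound to an oxygen on an aromatic ring accepts a phenyl bearing two substituents, and the swap to 5-chloro-2-methylphenyl gives a 55-fold lower number from compound 2 to compound 3 (1.74 log units; beyond the scatter) while leaving the number level with the fluoro compound, at a 1.5-fold lower number from compound 1 to compound 3 (0.16 log units; within the scatter). Of the three aryl groups at this place, only 3-cyanophenyl goes with the high number, so the earlier drop in inhibition does not extend to the other two groups, which differ in their substituents. No measurement here accounts for these differences.

Chloro and methyl entered together, so their separate contributions remain unknown, as does whether either alone would match the pair. On these data alone, it also remains open how a methoxy group, an amine or a carboxylic acid on this phenyl ring would behave.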